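This account rests on a few compounds, and the source may have more. Where it says the series, first, only, none or still open, it means among the compounds named here.

Working notes on a short series of hydroxamic acids sharing one core, tested in a functional assay on U-937 cells (Homo sapiens) for antiproliferative activity, read by MTT assay, with a stated time of 72 h; a lower number here means a stronger inhibitor, a higher number a weaker inhibitor. Compound 1 `COc1ccc(-c2noc(CCCCCCC(=O)NO)n2)cc1` gives 3650 nM. Compound 2 `O=C(CCCCCCc1nc(-c2ccc(C(F)(F)F)cc2)no1)NO` gives 2870 nM, and compound 3 `O=C(CCCCCCc1nc(-c2ccc(F)cc2)no1)NO` gives 1930 nM. Compound 3 holds the lowest of the three numbers, yet a 1.9-fold lower number from compound 1 to compound 3 (0.28 log units; within the scatter) and a 1.5-fold lower number from compound 2 to compound 3 (0.17 log units; within the scatter) both stay within the scatter, as does a 1.3-fold lower number from compound 1 to compound 2 (0.10 log units; within the scatter). Compound 4 `O=C(CCCCCCc1nc(-c2cccs2)no1)NO` differs from compound 3 by thiophen-2-yl in place of 4-fluorophenyl on an aromatic carbon. Among the measured compounds shown here, each measured step exchanges one substituent on the six-membered aromatic ring of carbon only; none exchanges that ring for another, so no measured step bears directly on this change, and the three small steps give no ground for a large effect. For compound 4 the expected step of a 1.0-fold higher number from compound 3 to compound 4 (0.02 log units; within the scatter) is therefore none beyond the scatter. Compound 4 is estimated at 2000 nM, with a range of 800 nM to 5000 nM.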

Compound 4, half-maximal inhibitory concentration: 320 nM
The estimate for compound 4 lay 6.3-fold (0.80 log units) above the measured number, and the stated range ends above it.
By their numbers in this assay, from the lowest: compound 4; then compounds 3, 2 and 1 (each within the scatter of the next).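

In this assay, among the compounds shown here, the exchange of 4-fluorophenyl for thiophen-2-yl gives a 6.0-fold lower number from compound 3 to compound 4 (0.78 log units; beyond the scatter) and is the only step beyond the scatter. At this position on the shared core, replacing the ring itself therefore changes the number more than the substituent exchanges among compounds 1, 2 and 3 did. No available measurement accounts for this step.

On these data alone, whether the step follows the ring sulfur, the five-membered ring or the loss of the six-membered ring stays open. Furan-2-yl, thiophen-3-yl and pyridin-2-yl at this position would help separate these readings.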